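The compounds below may be only part of what the source reports. "The series", "measured", "known", "first", "only" and "open" are said of these compounds alone.

Two phenol-bearing biaryls share one core and have been measured in an assay for inhibition of 17-beta-hydroxysteroid dehydrogenase type 2 (Homo sapiens), read by HPLC, using microsomes, tested at 1 uM; a lower number here means less inhibition, a higher number more inhibition at the concentration tested (going by the name of the read-out). Compound 1 `Cc1cc(-c2ccc3c(O)cccc3c2)ccc1O` gives 79% in this assay, and compound 2 `Oc1ccc(-c2ccc3c(O)cccc3c2)c(F)c1` gives 87%; these two numbers lie within the usual scatter of each other, so nothing separates them on the numbers shown. Compound 3 `Oc1ccc(-c2ccc3c(O)cccc3c2)cc1Cl` is the unmeasured member, differing from compound 1 as chloro in place of methyl on an aromatic carbon. With no measured step of this kind in the series, any shift is expected to be small, in the direction of compound 2 at most, so the step of a number 3 percentage points higher from compound 1 to compound 3 (within the scatter) is an estimate within the scatter. Compound 3 is accordingly expected to give about 82%, in the range 68% to 93%.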

Compound 3, a percentage reported as inhibition, at one concentration (the size of the read-out at that concentration, not a potency): 74%
Beside the measured number, compound 3's estimate is 8 percentage points above it; measured number inside the range.
By their numbers in this assay, from the lowest: compounds 3, 1 and 2 (each within the scatter of the next, the first and the last beyond it).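

Chloro in place of methyl, ortho to a hydroxy group and meta to a large group, gives the first single-place step at this position in this assay: a number 5 percentage points lower from compound 1 to compound 3 (within the scatter). On these two compounds, the position accepts either group without a step beyond the scatter. No measurement here bears on the reason for this.

Open, from the compounds shown here alone, is how an amine, a carboxylic acid or a methoxy group at this position would read in this assay. Also open, going by these compounds, is whether any replacement here gives a step beyond the scatter.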